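Trimethoxybenzoyl benzothiophenes: swapping chloro for methyl on the aryl

The source may report more compounds than this note shows. Statements on the series, on what has been measured and on what is new or still open speak of the compounds shown alone.

Three compounds share a core in which a trimethoxybenzoyl group sits on a fused sulfur-containing ring system, and they were tested in a functional assay on HL-60 cells (Homo sapiens) for antiproliferative activity, read by MTT assay, with a stated time of 72 h; on this read-out higher numbers stand for weaker inhibition and lower numbers for stronger inhibition. Compound 1 `COc1cc(C(=O)c2sc3ccccc3c2-c2ccc(Cl)cc2)cc(OC)c1OC` gives 3300 nM. Compound 2 `COc1cc(C(=O)c2sc3ccccc3c2-c2ccc(C)cc2)cc(OC)c1OC` gives 1400 nM; the change is methyl in place of chloro on an aromatic carbon, and the step was a 2.4-fold lower number from compound 1 to compound 2 (0.37 log units; beyond the scatter). Compound 3 `COc1cc(C(=O)c2sc3ccccc3c2Nc2ccc(Cl)cc2)cc(OC)c1OC` gives 5400 nM; here the core differs from compound 1 by (4-chlorophenyl)amino in place of 4-chlorophenyl on an aromatic carbon, and the step was a 1.6-fold higher number from compound 1 to compound 3 (0.21 log units; within the scatter). Between compound 2 and compound 3 the step was a 3.9-fold higher number from compound 2 to compound 3 (0.59 log units; beyond the scatter).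

Compound 4 `COc1cc(C(=O)c2sc3ccccc3c2Nc2ccc(C)cc2)cc(OC)c1OC` has not been measured. It differs from compound 3 by methyl in place of chloro on an aromatic carbon, the same change as from compound 1 to compound 2, made on the other core. The step from compound 3 to compound 4 in this assay is expected to be a 2.3-fold lower number from compound 3 to compound 4 (0.35 log units; beyond the scatter), resting on the earlier step of a 2.4-fold lower number from compound 1 to compound 2 (0.37 log units; beyond the scatter). Compound 4 is therefore expected to give about 2400 nM, between 1000 nM and 6000 nM.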

Compound 4, half-maximal inhibitory concentration: 4600 nM
Compound 4: middle estimate off by 1.9-fold (0.28 log units), on the low side; the measured number falls inside the stated range.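

The same change, methyl in place of chloro, gives a 1.2-fold lower number from compound 3 to compound 4 (0.07 log units; within the scatter) in this assay, and set beside the earlier step, the two cannot be told apart: the same change on two cores in this assay, a 2.4-fold lower number (0.37 log units; beyond the scatter) from compound 1 to compound 2 and a 1.2-fold lower number (0.07 log units; within the scatter) from compound 3 to compound 4, 2.0-fold (0.30 log units) apart, within the scatter of two such steps

This fits the change carrying over from one core to the other, but it rests on one pair per core and does not prove transfer, as the new step alone lies within the scatter. Separately, (4-methylphenyl)amino in place of 4-methylphenyl gives a 3.3-fold higher number from compound 2 to compound 4 (0.52 log units; beyond the scatter), while the step that changes two places at once gives a 1.4-fold higher number from compound 1 to compound 4 (0.14 log units; within the scatter).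

Going by these compounds, whether a fluoro, a methoxy or an amine in place of the chloro would behave alike on both cores remains open. So does whether the pattern holds on a third core.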